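The compounds below may be only part of what the source reports. "The series", "measured", "known", "first", "only" and "open" are said of these compounds alone.

Measured compounds:
compound 1, `COc1cc(=O)oc2cc(OCc3cccc(F)c3)ccc12`, 49%
compound 2, `CCOc1cc(=O)oc2cc(OCc3cccc(Br)c3)ccc12`, 2.5%
compound 3, `CC(=O)COc1cc(=O)oc2cc(OCc3cccc(Cl)c3)ccc12`, 22%

All three were tested in an assay on isolated protein (strain Sprague-Dawley) for inhibition of Amine oxidase [flavin-containing] A (Rattus norvegicus), read by spectrophotometry, with a stated time of 5 min, tested at 10 uM; on this read-out higher numbers stand for more inhibition at the one concentration tested (going by the name of the read-out) and lower numbers for less inhibition. Compound 3 gives 22% and stands second highest of the three: compound 1 lies clearly above it and compound 2 clearly below it, both gaps beyond the usual scatter. The next compound, compound 4, `O=Cc1cc(=O)oc2cc(OCc3cccc(Cl)c3)ccc12`, differs from compound 3 in one place: formyl in place of 2-oxopropoxy on an aromatic carbon. Within the data shown here, no step between two measured compounds isolates this change, so its direction cannot be read from the data. The step from compound 3 to compound 4 is expected to be a number 2 percentage points lower from compound 3 to compound 4 (within the scatter), not beyond the scatter. Compound 4 is therefore estimated at 20% in this assay, within a range from 2% to 48%.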

Compound 4, a percentage reported as inhibition, at one concentration (the size of the read-out at that concentration, not a potency): 14%
Beside the measured number, compound 4's estimate is 6 percentage points above it; the measured number falls inside the stated range.
By their numbers in this assay, from the lowest: compound 2; then compounds 4 and 3 (each within the scatter of the next); then compound 1.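

Swapping 2-oxopropoxy for formyl on this aromatic carbon opposite the ring oxygen gives, in this assay, a number 8 percentage points lower from compound 3 to compound 4 (within the scatter), the first direct reading at this position. In this one pair, therefore, a shorter group with one hydrogen-bond acceptor fewer leaves the inhibition indistinguishable. No measurement at hand accounts for this outcome.

Going by these compounds, it remains open whether an amine or a carboxylic acid here would stay within the scatter of compound 3 or move beyond it. A longer chain ending in a carbonyl is equally unresolved.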